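This account rests on a few compounds, and the source may have more. Where it says the series, first, only, none or still open, it means among the compounds named here.

Measured so far in an assay on CHO cells for displacement of a labelled ligand from adenosine receptor A3 (Homo sapiens), read by scintillation counting, with a stated time of 3 h; a higher number here means a weaker inhibitor, a lower number a stronger inhibitor: compound 1 `Cc1ccccc1-c1nc2c(NC3CCCC3)ncnc2n1C` gives 3000 nM; compound 2 `Cc1cccc(-c2nc3c(NC4CCCC4)ncnc3n2C)c1` gives 510 nM.

For the measured compounds named here, of the two numbers known, compound 2 stands at the lower one. Going by the values given here, the only measured step, a 5.9-fold lower number from compound 1 to compound 2 (0.77 log units; beyond the scatter), runs between them and shows that the aryl group on the shared core matters: shifting the methyl on that ring changed the number well beyond the scatter. Compound 3 `Cn1c(-c2ccc(F)cc2)nc2c(NC3CCCC3)ncnc21` carries the same core and the same cyclopentylamino group but a different aryl ring; the change is 4-fluorophenyl in place of 3-methylphenyl on an aromatic carbon. Among the compounds with values here, that step from compound 1 to compound 2 bears on compound 3 only loosely: it concerns the same ring but moves a methyl rather than exchanging it for fluorine, and no measured pair tests a 4-fluorophenyl at all. Without a direct precedent, the expected change in this assay is small, most likely within the scatter, with the range set wide to allow either direction. For compound 3 the estimate is 450 nM, between 120 nM and 1700 nM, a step of a 1.1-fold lower number from compound 2 to compound 3 (0.05 log units; within the scatter) expected from compound 2.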

Compound 3, inhibition constant: 1140 nM
Estimate against measurement, compound 3: 2.5-fold (0.40 log units) below, and the stated range covers the measured number.
By their numbers in this assay, from the lowest: compound 2; then compound 3; then compound 1.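

On the aromatic carbon between two ring nitrogen atoms, 4-fluorophenyl in place of 3-methylphenyl gives a modest change in this assay (a 2.2-fold higher number from compound 2 to compound 3 (0.35 log units; beyond the scatter)), while 4-fluorophenyl in place of 2-methylphenyl moves the number the other way (a 2.6-fold lower number from compound 1 to compound 3 (0.42 log units; beyond the scatter)). The earlier compounds shown here showed only that moving a methyl on this ring changes the number, whereas these steps show that a ring carrying fluorine instead of methyl also differs from both methylphenyl rings beyond the scatter, and that it falls inside the span they set, even though all three aryl groups have the same count of heavy atoms and no hydrogen-bond donors or acceptors. No independent measurement at hand accounts for these differences.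

The compounds shown cannot separate the exchange of methyl for fluorine from the shift of the substituent on the ring, since 4-fluorophenyl differs from each methylphenyl group in both respects. They also leave open how a plain phenyl ring, or an aryl ring bearing an amine or a carboxylic acid, would read at this position.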